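This account rests on a few compounds, and the source may have more. Where it says the series, first, only, none or still open, it means among the compounds named here.

Compound 1 `CNc1ncnc2c1c(-c1ccco1)cn2[C@@H]1O[C@H](CO)[C@@H](O)[C@H]1O`: 2570 nM
Compound 2 `CN(C)c1ncnc2c1c(-c1ccsc1)cn2[C@@H]1O[C@H](CO)[C@@H](O)[C@H]1O`: > 20000 nM
Compound 3 `Nc1nc(N)c2c(-c3ccco3)cn([C@@H]3O[C@H](CO)[C@@H](O)[C@H]3O)c2n1`: > 20000 nM

These three compounds were tested in a functional assay on A549 cells (Homo sapiens), read by MTT assay, with a stated time of 72 h; a higher number here means a weaker inhibitor, a lower number a stronger inhibitor. Only compound 1 has a true number there. The entry for compound 2 is a limit, not a number. Compound 3 has no number either: its > 20000 nM is a limit.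

The next compound is compound 4 `Nc1nc(N)c2c(-c3cc4ccccc4o3)cn([C@@H]3O[C@H](CO)[C@@H](O)[C@H]3O)c2n1`, which alters a single group of compound 3: 1-benzofuran-2-yl in place of furan-2-yl on an aromatic carbon. The change is 1-benzofuran-2-yl in place of furan-2-yl on an aromatic carbon. For the measured compounds named here, no measured pair shows what such a swap does in this assay, so any forecast is rough. A small shift toward a lower number is expected, or none beyond the scatter, and another limit is quite likely. That expectation rests on (the limit of > 20000 nM in this assay, at which 2 of the 3 values shown sit). The estimated change is an at least 1.1-fold lower number from compound 3 to compound 4 (0.04 log units; that floor lies within the scatter). For compound 4 the expected value is 18000 nM, with an estimated range from 5000 nM to 40000 nM.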

Compound 4, half-maximal inhibitory concentration: > 20000 nM
Compound 4 was reported as a limit (the forecaster's own chance of this, stated with the estimate: 70%); middle value at least 1.1-fold (0.04 log units) away from the limit.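

Compound 3 and compound 4 are both reported in this assay only as limits, not as numbers, and no step can be read between them. The compounds shown leave open whether 1-benzofuran-2-yl in place of furan-2-yl changes the activity at all.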